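Trifluoromethyl for fluoro on the phenoxy ring

The source may hold more compounds than are shown below. What is called first, only, known or untested is meant among the compounds shown, and "the series" means these compounds.

Compound 1 `COC(=O)c1ccc(-c2nnn(CC(=O)C(C)Oc3ccc(Oc4ccc(C(F)(F)F)cc4)cc3)n2)cc1` gives 6.2. Compound 2 `CCCCCCCCc1ccc(OC(C)C(=O)Cn2nnc(-c3ccc(C(=O)O)cc3)n2)cc1` gives 5.9. Compound 3 `CC(Oc1ccc(Oc2ccc(F)cc2)cc1)C(=O)Cn1nnc(-c2ccc(C(=O)O)cc2)n1` gives 2.7.

In a physicochemical assay for lipophilicity, read by HPLC, tested at 5 mM (a higher number here means a more lipophilic compound, a lower number a more polar compound), compound 3 stands lowest of the three numbers, nearest to compound 2 and furthest from compound 1. Compound 4 `CC(Oc1ccc(Oc2ccc(C(F)(F)F)cc2)cc1)C(=O)Cn1nnc(-c2ccc(C(=O)O)cc2)n1` differs from compound 3 by one change: trifluoromethyl in place of fluoro on an aromatic carbon. Among the compounds with values here, no measured step shows this exact exchange. Within the data shown here, the only measured step, a number 3.20 log units lower from compound 2 to compound 3 (beyond the scatter), concerns a different group at the same aromatic position and so gives only a rough sense of how far a change there can move the number. Compound 1, which differs from compound 4 in a second place as well, shows a far higher value than compound 3. For compound 4 a moderate rise is expected, a number 0.80 log units higher from compound 3 to compound 4 (beyond the scatter), giving an estimated 3.5, with a range from 2.9 to 4.3.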

Compound 4, partition coefficient: 3.5
For compound 4 middle estimate and measured number coincide at the digits printed; low and high end bracket the measured number.
By their numbers in this assay, from the lowest: compound 3; then compound 4; then compounds 2 and 1 (each within the scatter of the next).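

In this assay, trifluoromethyl in place of fluoro gives a number 0.80 log units higher from compound 3 to compound 4 (beyond the scatter), the first step measured at this position that keeps the phenoxy ring, and it is modest. Octyl in place of the whole 4-(trifluoromethyl)phenoxy group remains far apart, with a number 2.40 log units lower from compound 2 to compound 4 (beyond the scatter), and a change elsewhere, hydrogen for the methyl of the ester, gives a large step, a number 2.70 log units lower from compound 1 to compound 4 (beyond the scatter). The data shown give no reason for any of these steps.

From the compounds shown here alone, whether chloro or methoxy on this aromatic carbon would read closer to fluoro or to trifluoromethyl stays open, as does where a shorter alkyl chain would fall.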